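Swapping Pyrrolidin-1-yl for Piperidin-1-yl on a Cinnamate Ester

The compounds below may be only part of what the source reports. "The series", "measured", "known", "first", "only" and "open" are said of these compounds alone.

Measured in an ADME assay on L6 cells (Rattus norvegicus) for cytotoxicity, with a stated time of 72 h; a lower number here means a stronger inhibitor, a higher number a weaker inhibitor:
- compound 1 `CC(C)(C)C(=O)OC1CC2(N3CCCCC3)CC(c3ccccc3)C1C(c1ccccc1)C2`: 12000 nM
- compound 2 `O=C(/C=C/c1ccccc1)OC1CC2(N3CCCC3)CC(c3ccccc3)C1C(c1ccccc1)C2`: 3500 nM
- compound 3 `OC1CC2(N3CCCC3)CC(c3ccccc3)C1C(c1ccccc1)C2`: 26800 nM

Compound 2 gives the lowest number of the three, and the gaps to the other two lie beyond the scatter. Compound 4 `O=C(/C=C/c1ccccc1)OC1CC2(N3CCCCC3)CC(c3ccccc3)C1C(c1ccccc1)C2` carries piperidin-1-yl in place of pyrrolidin-1-yl on a saturated ring carbon. Among the measured compounds shown here, the only measured step, a 7.7-fold higher number from compound 2 to compound 3 (0.88 log units; beyond the scatter), concerns the (2-phenylethenyl)carbonyl group on oxygen, so it bears on a different place and says little about this change. Compound 1 does carry piperidin-1-yl and gives 12000 nM, but it also has a different ester, so the amine's share in its value cannot be separated. For the measured compounds named here, no measured pair isolates this swap. With nothing pointing either way, no change beyond the scatter is expected in this assay. The expected step is a 1.1-fold higher number from compound 2 to compound 4 (0.06 log units; within the scatter). For compound 4 the estimated value is 4000 nM, with an expected range from 1700 nM to 9500 nM.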

Compound 4, half-maximal inhibitory concentration: 10500 nM
Estimate against measurement, compound 4: 2.6-fold (0.42 log units) below; the whole stated range lies below it.
By their numbers in this assay, from the lowest: compound 2; then compounds 4 and 1 (each within the scatter of the next); then compound 3.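

In this assay, among the compounds shown here, the amine on the saturated ring carbon proves to matter: with the (2-phenylethenyl)carbonyl ester held constant, piperidin-1-yl in place of pyrrolidin-1-yl gives a 3.0-fold higher number from compound 2 to compound 4 (0.48 log units; beyond the scatter), the first step to isolate this swap. With piperidin-1-yl held constant, 2-phenylethenyl in place of tert-butyl on the carbonyl carbon gives a 1.1-fold lower number from compound 1 to compound 4 (0.06 log units; within the scatter), so these two ester groups are not told apart on that amine, and the low number of compound 2 is tied to its pyrrolidin-1-yl group. Nothing available explains why the swap shifts the number.

Going by these compounds, whether the same swap has a similar effect with the tert-butyl ester or the free hydroxyl remains open. So does the outcome with a morpholine or dimethylamino group on this carbon.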